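A few compounds are considered here, and "the series" means these few. Any claim that something is new, unique, unknown or untested is made for them only; others in the source may bear on it.

Series values in an assay on isolated protein for inhibition of protein kinase C zeta type (Homo sapiens), read by 33P incorporation, tested at 50 uM; on this read-out lower numbers stand for a weaker effect and higher numbers for a stronger effect at the one concentration tested:

compound 1, `O=C(O)CC(Cc1nc2cc(F)ccc2[nH]1)c1ccc(Cl)cc1`: 0%
compound 2, `O=C(O)CC(Cc1nc2cc(Br)ccc2[nH]1)c1ccc(Cl)cc1`: 25%
compound 3, `Cc1ccc2[nH]c(CC(CC(=O)O)c3ccc(Cl)cc3)nc2c1`: 0%

Compound 2 stands highest of the three numbers; its nearest neighbour is compound 1 at a number 25 percentage points higher from compound 1 to compound 2 (beyond the scatter), and compound 3 lies equally far off, a number 25 percentage points lower from compound 2 to compound 3 (beyond the scatter). Compounds 1 and 3 are within the scatter of each other, no change at the digits printed from compound 1 to compound 3 (within the scatter), so neither can be ordered against the other. Only the bromo substituent has given a reading above the scatter.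

Compound 4, `COc1ccc2[nH]c(CC(CC(=O)O)c3ccc(Cl)cc3)nc2c1`, is the next member. Relative to compound 2 it differs as follows: methoxy in place of bromo on an aromatic carbon.

Among the measured compounds shown here, two measured steps bear on this change, both touching the same aromatic carbon. Going from bromo to fluoro, the reverse of a number 25 percentage points higher from compound 1 to compound 2 (beyond the scatter), and from bromo to methyl, a number 25 percentage points lower from compound 2 to compound 3 (beyond the scatter), each removed the whole signal. For the measured compounds named here, no step involving methoxy has been measured, so its effect rests on the analogy that every replacement of bromo so far has cost the activity. On that basis a loss of similar size is expected, a number 20 percentage points lower from compound 2 to compound 4 (beyond the scatter).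

Compound 4 is therefore estimated at 5%, with a range from 0% to 25%.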

Compound 4, a percentage reported as inhibition, at one concentration (the size of the read-out at that concentration, not a potency): 0%
Compound 4: the middle estimate sits 5 percentage points above what was measured, within the range that was stated.
By their numbers in this assay, from the lowest: compounds 1, 3 and 4 (each within the scatter of the next); then compound 2.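

Methoxy in place of bromo gives a number 25 percentage points lower from compound 2 to compound 4 (beyond the scatter) in this assay, so a replacement that brings in a hydrogen-bond acceptor and two heavy atoms for one also fails to keep the signal seen with bromo on this aromatic carbon. Methoxy cannot be separated from the other two replacements, with no change at the digits printed from compound 3 to compound 4 (within the scatter) and no change at the digits printed from compound 1 to compound 4 (within the scatter), so fluoro, methyl and methoxy stand together without order, and bromo remains the only one of the four substituents with a reading beyond the scatter. Nothing available accounts for bromo standing apart from these three.

On these data alone, whether the reading of compound 2 is particular to bromo or is shared by other groups on this aromatic carbon, such as chloro, iodo or an amine, stays open. With a read-out at a single concentration, the series also gives no potency for compound 2, and it leaves open whether the substituent would matter at another concentration.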